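This account rests on a few compounds, and the source may have more. Where it says the series, first, only, none or still open, it means among the compounds named here.

Compound 1 `Cc1cccc2sc(NC(=O)CCN3CCN(C(C)(C)C)CC3)nc12`: no result reported in this assay.
Compound 2 `Cc1cccc2sc(NC(=O)CCN3CCN(CC4CCCCC4)CC3)nc12`: no result reported in this assay.
Compound 3 `Cc1cccc2sc(NC(=O)CCN3CCN(c4ccncc4)CC3)nc12`: 1130 nM in this assay.

These three compounds share one core and differ only in the group on the amine nitrogen in a ring. In an assay on HEK293 cells for antagonist activity at P2X purinoceptor 7 (Homo sapiens), read by fluorescence, with stated times of 30 min and 120 min (on this read-out higher numbers stand for weaker inhibition and lower numbers for stronger inhibition), compound 1 has no single number, and compound 2 likewise has none, so where compound 1 stands on the numbers shown cannot be said; only compound 3 gives 1130 nM in this assay. The step to compound 4 `Cc1cccc2sc(NC(=O)CCN3CCN(c4ncccn4)CC3)nc12` makes one change: pyrimidin-2-yl in place of tert-butyl on an amine nitrogen in a ring. Among the compounds with values here, with no number for compound 1, no direction for this step can be named; the expectation for compound 4 rests on compound 3, because compound 3 gives 1130 nM. Compound 4 is estimated at 1500 nM, with a range of 400 nM to 6000 nM.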

Compound 4, half-maximal inhibitory concentration: 1330 nM
Estimate against measurement, compound 4: 1.1-fold (0.05 log units) above; the measured number falls inside the stated range.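

In this assay, within the data shown here, pyrimidin-2-yl in place of pyridin-4-yl on the amine nitrogen in a ring gives a 1.2-fold higher number from compound 3 to compound 4 (0.07 log units; within the scatter), the first comparison that can be read at this position. The two aromatic rings, with their different ring nitrogens, therefore read alike here. Nothing at hand offers an explanation for this result. The steps from compound 1 and compound 2 cannot be read, as neither has a number. Open, going by these compounds, is how a plain phenyl ring or an acetyl group on this nitrogen would read.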